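The compounds below may be only part of what the source reports. "The series", "measured", "known", "first", "only" and "open" are said of these compounds alone.

Measured in a functional assay on HT-29 cells (Homo sapiens) for inhibition; on this read-out higher numbers stand for weaker inhibition and lower numbers for stronger inhibition:
- compound 1 `COc1ccc(/C=C\c2ccc3ccccc3c2)cc1N`: 1820 nM
- compound 2 `COc1cc(/C=C\c2ccc3ccccc3c2)cc([N+](=O)[O-])c1OC`: 420 nM
- compound 3 `COc1cc(/C=C\c2ccc3ccccc3c2)cc(N)c1OC`: 330 nM

Compound 3, at 330 nM, cannot be separated from compound 2 but stands clear of compound 1. The change of methoxy in place of hydrogen on an aromatic carbon gives a 5.5-fold lower number from compound 1 to compound 3 (0.74 log units; beyond the scatter). That step is a different change and bears only indirectly on what follows.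

Compound 4 `COc1cc(/C=C\c2ccc3ccccc3c2)cc(NC(C)=O)c1OC` is still unmeasured. It carries acetyl in place of hydrogen on a nitrogen on an aromatic ring, amino to acetamido: acetyl in place of hydrogen on a nitrogen on an aromatic ring.

The closest evidence is amino in place of nitro on an aromatic carbon, which gives a 1.3-fold lower number from compound 2 to compound 3 (0.10 log units; within the scatter). Among the measured compounds shown here, no measured compound carries acetamido, so the direction is uncertain. A modest move towards a higher number is expected, possibly none beyond the scatter.

The expected change is a 1.8-fold higher number from compound 3 to compound 4 (0.26 log units; within the scatter). Compound 4 is estimated at 600 nM, with an expected range of 200 nM to 2000 nM.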

Compound 4, half-maximal inhibitory concentration: > 5000 nM
Compound 4: only a limit was reported; the forecaster's own chance of this, stated with the estimate: 5%; at least 8.3-fold (0.92 log units) between middle value and limit.
By their numbers in this assay, from the lowest: compounds 3 and 2 (each within the scatter of the next); then compound 1. At a limit, above all of these: compound 4.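

In this assay compound 4 gives > 5000 nM, which is a limit of the assay and not a number: the limit of > 5000 nM in this assay, at which 1 of the 4 values shown sits. Acetyl in place of hydrogen on the nitrogen gives an at least 15-fold higher number from compound 3 to compound 4 (1.18 log units; beyond the scatter), whereas amino in place of nitro gave only a 1.3-fold lower number from compound 2 to compound 3 (0.10 log units; within the scatter). Acetamido in place of nitro gives an at least 11-fold higher number from compound 2 to compound 4 (1.07 log units; beyond the scatter), so this position, where nitro and amino could not be separated, does not take every group alike.

Going by these compounds, both new steps rest on a limit, so their true size stays open. Among the compounds shown here, with acetyl as the only group on this nitrogen, it also stays open whether a single methyl on the nitrogen, a methanesulfonyl group or a longer acyl chain such as propionyl would read like amino or like acetamido.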